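Working notes on solubility, compound 3 to compound 4

This account rests on a few compounds, and the source may have more. Where it says the series, first, only, none or still open, it means among the compounds named here.

In a physicochemical assay for solubility (a higher number here means a more soluble compound, a lower number a less soluble compound), compound 1 `COc1cc2cc(C(=O)CCCCC3CC[N+](C)(Cc4ccccc4)CC3)sc2cc1OC` gives 1000 ug/mL, compound 2 `COc1cc2cc(C(=O)CCC3CC[N+](C)(Cc4ccc([N+](=O)[O-])o4)CC3)sc2cc1OC` gives 600 ug/mL, and compound 3 `C=CC[n+]1ccc(CCC(=O)c2cc3cc(OC)c(OC)cc3s2)cc1` gives 25000 ug/mL. Compound 3 holds the highest number of the three; its nearest neighbour is compound 1, and the gap to compound 2 is wider still, both gaps lying beyond the usual scatter. For the measured compounds named here, no step between two measured compounds that differ in a single place is available, so nothing is known of how one change alone moves this assay.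

Compound 4 `COC(=O)c1ccc(C[n+]2ccc(CCC(=O)c3cc4cc(OC)c(OC)cc4s3)cc2)cc1` differs from compound 3 in one place: 4-(methoxycarbonyl)phenyl in place of vinyl on a saturated chain carbon bound to an aromatic nitrogen. The change brings in an aromatic ring and an ester where a short vinyl sat. The expectation for compound 4 is a drop in this assay, of a size beyond the scatter, an 8.3-fold lower number from compound 3 to compound 4 (0.92 log units; beyond the scatter). Compound 4 is therefore estimated at 3000 ug/mL, with a range from 800 ug/mL to 12000 ug/mL.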

Compound 4, solubility: 3500 ug/mL
Beside the measured number, compound 4's estimate is 1.2-fold (0.07 log units) below it; low and high end bracket the measured number.
By their numbers in this assay, from the lowest: compounds 2 and 1 (each within the scatter of the next); then compound 4; then compound 3.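

For the compounds shown here, this is the first single-place step. At the saturated chain carbon bound to an aromatic nitrogen, in this assay, 4-(methoxycarbonyl)phenyl in place of vinyl gives a 7.1-fold lower number from compound 3 to compound 4 (0.85 log units; beyond the scatter), a modest step that lies beyond the scatter. This position therefore registers in this read-out even with the rest of the structure held fixed, but the change brings in an aromatic ring and an ester together, and no measurement on hand separates the two or explains the step.

Open, going by these compounds, is whether plain phenyl or a carboxylic acid in place of the ester would land nearer compound 3 or compound 4. Also open, on these data alone, is whether an amine or a longer chain at this place would move the number as far, and whether the same change would act alike on the core of compound 1.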